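A few compounds are considered here, and "the series" means these few. Any claim that something is new, unique, unknown or untested is made for them only; others in the source may bear on it.

Measured compounds: compound 1 `C#CCCOC(=O)/C=C(C)/C=C/CC(C)CCCC(C)(C)OC` gives 5.2; compound 2 `CCOC(C)(C)CCCC(C)C/C=C/C(C)=C/C(=O)OC(C)C` gives 6.49; compound 3 `CCNC(=O)OC(C)(C)CCCC(C)C/C=C/C(C)=C/C(=O)OC(C)C` gives 6.06 in a physicochemical assay for lipophilicity; on this read-out lower numbers stand for lower lipophilicity and higher numbers for higher lipophilicity.

Compound 1 has the lowest of the three numbers; compound 3 stands nearer to it and compound 2 furthest, both beyond the scatter. Compound 4 `CCN(CC)C(=O)/C=C(C)/C=C/CC(C)CCCC(C)(C)OC` is not yet measured. It differs from compound 1 as follows: diethylamino in place of (but-3-yn-1-yl)oxy on a carbonyl carbon. Going by the values given here, the one measured step, a number 0.43 log units lower from compound 2 to compound 3 (beyond the scatter), concerns a change on an oxygen on a saturated carbon, not on a carbonyl carbon, so no measured step bears directly on the change from compound 1 to compound 4. The expectation rests on the structural change alone: a downward step, a number 0.80 log units lower from compound 1 to compound 4 (beyond the scatter), is expected. For compound 4 a value of 4.4 is estimated, between 3.7 and 5.1.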

Compound 4, partition coefficient: 4.82
Compound 4: the middle estimate sits 0.42 log units below what was measured; measured number inside the range.
By their numbers in this assay, from the lowest: compound 4; then compound 1; then compound 3; then compound 2.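

In this assay, going by these compounds alone, this is the first measured change on a carbonyl carbon: diethylamino in place of (but-3-yn-1-yl)oxy gives a number 0.38 log units lower from compound 1 to compound 4 (beyond the scatter) and makes compound 4 the lowest of the series so far. Both groups hold 5 heavy atoms, so the shift comes without a change in that count. No available evidence explains the step. Still open, on these data alone, is how dimethylamino, a cyclic amine such as piperidine or a free carboxylic acid on this carbonyl carbon would compare with diethylamino.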